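Two Measured Esters and a Third Still to Test

The source may report more compounds than this note shows. Statements on the series, on what has been measured and on what is new or still open speak of the compounds shown alone.

Compound 1 `COC(=O)c1cccc(OC)c1OC(=O)COc1cc(O)c2c(=O)cc(-c3ccccc3)oc2c1` and compound 2 `COC(=O)c1cc(O)ccc1OC(=O)COc1cc(O)c2c(=O)cc(-c3ccccc3)oc2c1` share a common core and differ only in the aromatic ester group sitting on an oxygen next to a carbonyl group. In an ADME assay on cells (T-cell, Mus musculus, strain BALB/c) for cytotoxicity, read by MTT assay, with a stated time of 48 h (on this read-out lower numbers stand for higher toxicity in this test and higher numbers for lower toxicity in this test), compound 1 gives 196000 nM. In this assay compound 2 gives 263000 nM, the higher of the two numbers, but its gap to compound 1 lies within the usual scatter, so the two cannot be ranked. Compound 3 `COC(=O)c1cccc(C)c1OC(=O)COc1cc(O)c2c(=O)cc(-c3ccccc3)oc2c1` carries the change (a group of 11 heavy atoms (9 carbon, 2 oxygen; one six-membered aromatic ring of carbon only) in place of a group of 11 heavy atoms (8 carbon, 3 oxygen; one six-membered aromatic ring of carbon only), on an oxygen next to a carbonyl group). Among the measured compounds shown here, no measured pair shows this kind of exchange, so there is no direct guide. Because compound 1 gives 196000 nM with its own different ester group, a large shift is not anticipated. The step of a 1.2-fold lower number from compound 2 to compound 3 (0.08 log units; within the scatter) in this assay is expected to be none beyond the scatter. Compound 3 is therefore estimated to give about 220000 nM in this assay, within a range from 100000 nM to 450000 nM.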

Compound 3, half-maximal cytotoxic concentration: 299000 nM
Estimate against measurement, compound 3: 1.4-fold (0.13 log units) below, within the range that was stated.
By their numbers in this assay, from the lowest: compounds 1, 2 and 3 (each within the scatter of the next).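

In this assay the exchange of one aromatic ester group for another, on an oxygen next to a carbonyl group, gives a 1.1-fold higher number from compound 2 to compound 3 (0.06 log units; within the scatter) and so shows no real difference, even though the group that leaves has 1 hydrogen-bond donor and the group that enters has 0 hydrogen-bond donors. Methyl in place of methoxy on an aromatic carbon gives a 1.5-fold higher number from compound 1 to compound 3 (0.18 log units; within the scatter) and likewise shows no real difference. Nothing measured here speaks to the reason for this.

All three compounds carry a six-membered aromatic ring of carbon only in this place, and their numbers stay within the scatter of the next. Going by these compounds, whether a group bearing an amine or a carboxylic acid in this place would shift the number beyond the scatter remains open.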